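The compounds below may be only part of what the source reports. "The series", "measured", "known", "first", "only" and "open" are said of these compounds alone.

Working notes on the series. In a functional assay on HT-29 cells (Homo sapiens) for cytotoxicity, read by MTT assay, with a stated time of 72 h (a higher number here means a weaker inhibitor, a lower number a stronger inhibitor), compound 1 `CN1C/C(=C\c2ccccc2F)C(=O)/C(=C/c2ccccc2F)C1` gives 2200 nM, and compound 2 `CN1C/C(=C\c2cc(F)c(F)cc2F)C(=O)/C(=C/c2cc(F)c(F)cc2F)C1` gives 840 nM. Compound 2 holds the lower of the two numbers, and its gap to compound 1 lies beyond the scatter. Compound 3 `CCN1C/C(=C\c2cc(F)c(F)cc2F)C(=O)/C(=C/c2cc(F)c(F)cc2F)C1` has not yet been measured. It differs from compound 2 by methyl in place of hydrogen on a saturated chain carbon bound to an amine nitrogen in a ring, which reads as methyl to ethyl. Going by the values given here, no measured pair shows a change of this kind, so the expectation rests only on compound 2 at 840 nM. In this assay the estimated 1.1-fold lower number from compound 2 to compound 3 (0.02 log units; within the scatter) is expected to stay within the scatter, with no direction favoured. For compound 3 the estimated value is 800 nM, with an expected range of 350 nM to 1800 nM.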

Compound 3, half-maximal inhibitory concentration: 690 nM
For compound 3 the middle estimate is 1.2-fold (0.06 log units) above the measured one; the range from low to high includes it.
By their numbers in this assay, from the lowest: compounds 3 and 2 (each within the scatter of the next); then compound 1.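

In this assay, the step at this position is a 1.2-fold lower number from compound 2 to compound 3 (0.09 log units; within the scatter), which gives the series its first reading of methyl in place of hydrogen on a saturated chain carbon bound to an amine nitrogen in a ring. Going by these compounds alone, the change, read as methyl to ethyl, stays within the scatter, so this one added carbon leaves the number of compound 2 effectively unchanged, something no earlier pair could show. Nothing available explains this result.

Open, on these data alone, is whether a longer chain such as propyl, or a chain ending in an amine or a carboxylic acid, would also stay within the scatter at this place. Also open, as far as these compounds go, is whether methyl to ethyl would read the same on the core of compound 1.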